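A few compounds are considered here, and "the series" means these few. Any claim that something is new, unique, unknown or untested is made for them only; others in the source may bear on it.

Compound 3 `O=C(Nc1cc2c(Nc3ccc(F)c(Cl)c3)ncnc2cc1O[C@H]1CCOC1)N1CCC(N2CCCC2)CC1` gives the lowest of the three numbers measured in a functional assay on A-431 cells (Homo sapiens) for antiproliferative activity, read by sulforhodamine B assay, with a stated time of 72 h (on this read-out lower numbers stand for stronger inhibition and higher numbers for weaker inhibition), namely 317 nM. Compound 1 `CCN(CC)CCN(C)C(=O)Nc1cc2c(Nc3ccc(F)c(Cl)c3)ncnc2cc1O[C@H]1CCOC1` gives 481 nM in this assay, and the two lie within the scatter of each other, as a 1.5-fold lower number from compound 1 to compound 3 (0.18 log units; within the scatter) shows. Compound 2 `O=C(Nc1cc2c(Nc3ccc(F)c(Cl)c3)ncnc2cc1O[C@H]1CCOC1)N1CCC(F)CC1` gives 3040 nM in this assay, and the step of a 9.6-fold lower number from compound 2 to compound 3 (0.98 log units; beyond the scatter) is beyond the scatter, as is a 6.3-fold higher number from compound 1 to compound 2 (0.80 log units; beyond the scatter).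

Compound 4 `C#CCNC(=O)Nc1cc2c(Nc3ccc(F)c(Cl)c3)ncnc2cc1O[C@H]1CCOC1` differs from compound 3 in one place: propargylamino in place of 4-(pyrrolidin-1-yl)piperidin-1-yl on a carbonyl carbon. Both measured steps bear on this change. In compound 1 and compound 3 the group on the carbonyl carbon carries a basic nitrogen, and both give the lower numbers; compound 2 lacks such a nitrogen and gives the higher number. Propargylamino likewise carries no basic nitrogen, so the expectation is a step towards a higher number in this assay, of a size near a 9.6-fold lower number from compound 2 to compound 3 (0.98 log units; beyond the scatter) reversed, and in the same direction as that of a 6.3-fold higher number from compound 1 to compound 2 (0.80 log units; beyond the scatter). Compound 4 is therefore expected to give 2000 nM in this assay, with a range from 600 nM to 6500 nM, which is an expected step of a 6.3-fold higher number from compound 3 to compound 4 (0.80 log units; beyond the scatter).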

Compound 4, half-maximal inhibitory concentration: 3730 nM
For compound 4 the middle estimate is 1.9-fold (0.27 log units) below the measured one, within the range that was stated.
By their numbers in this assay, from the lowest: compounds 3 and 1 (each within the scatter of the next); then compounds 2 and 4 (each within the scatter of the next).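

On the carbonyl carbon in this assay, propargylamino does not hold the level of the 4-(pyrrolidin-1-yl)piperidin-1-yl group, with a 12-fold higher number from compound 3 to compound 4 (1.07 log units; beyond the scatter), or of the (2-(diethylamino)ethyl)(methyl)amino group, with a 7.8-fold higher number from compound 1 to compound 4 (0.89 log units; beyond the scatter). It stands level with 4-fluoropiperidin-1-yl, with a 1.2-fold higher number from compound 2 to compound 4 (0.09 log units; within the scatter), so the presence of a ring does not sort these four compounds: an open-chain group and a ring-bearing group appear in the lower pair, and likewise in the higher pair. No measurement shown here accounts for this grouping. As far as these compounds go, it remains open whether a dimethylamino group at the end of the propargyl chain would bring the number back towards that of compound 1. From the compounds shown here alone, the effect of a morpholine ring or a carboxylic acid on this carbonyl carbon also remains open.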